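The compounds below may be only part of what the source reports. "The series", "measured", "known", "first", "only" and "open" are said of these compounds alone.

Measured in a functional assay on SK-BR-3 cells (Homo sapiens) for antiproliferative activity; a lower number here means a stronger inhibitor, a higher number a weaker inhibitor:
- compound 1 `CC(C)=CCc1cc(C(=O)Nc2cc3ccc(OCCCN(C)C(C)(C)C)c(C)c3oc2=O)ccc1O`: 880 nM
- compound 2 `CC(C)=CCc1cc(C(=O)Nc2cc3ccc(OCCCNCC(N)=O)c(C)c3oc2=O)ccc1O`: 2290 nM

Of the two numbers, compound 2 holds the higher, so it is the weaker inhibitor of the pair. Compound 3 `CC(C)=CCc1cc(C(=O)Nc2cc3ccc(OCCCNc4ccccc4)c(C)c3oc2=O)ccc1O` has phenyl in place of carbamoylmethyl on an amine nitrogen. Among the compounds with values here, the only measured step at this amine is a 2.6-fold higher number from compound 1 to compound 2 (0.42 log units; beyond the scatter), and it introduced carbamoylmethyl. Within the data shown here, no compound with phenyl there has been measured, so this is only a loose guide. Removing carbamoylmethyl is expected to bring a similarly modest move to a lower number in this assay. The expected step is a 1.9-fold lower number from compound 2 to compound 3 (0.28 log units; within the scatter). Compound 3 is estimated at 1200 nM, within a range of 500 nM to 2900 nM.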

Compound 3, half-maximal inhibitory concentration: > 50000 nM
Compound 3: only a limit was reported; the forecaster's own chance of this, stated with the estimate: 3%; at least 41-fold (1.61 log units) between middle value and limit.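

In this assay, the reading for compound 3 is a limit and not a number: the limit of > 50000 nM in this assay, at which 1 of the 3 values shown sits. Even so, phenyl in place of carbamoylmethyl on the amine nitrogen gives an at least 21-fold higher number from compound 2 to compound 3 (1.33 log units; beyond the scatter), and anilino in place of methyl(tert-butyl)amino gives an at least 56-fold higher number from compound 1 to compound 3 (1.75 log units; beyond the scatter). The group on this nitrogen can therefore change the antiproliferative reading far more than the modest step between compound 1 and compound 2 suggested.

The compounds shown leave open whether the phenyl ring itself or its direct attachment to the nitrogen accounts for this. A benzylamino group, which sets a carbon between ring and nitrogen, would separate the two.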